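This account rests on a few compounds, and the source may have more. Where it says the series, first, only, none or still open, it means among the compounds named here.

Compound 1 `O=C1O/C(=C\Cn2cc(-c3cc(F)cc(F)c3)nn2)C(OCc2ccccc2)=C1OCc1ccccc1` gives 17700 nM in a functional assay on HeLa cells (Homo sapiens) for antiproliferative activity, read by MTT assay, with a stated time of 72 h; a lower number here means a stronger inhibitor, a higher number a weaker inhibitor. Compound 2 `COc1ccc(-c2cn(C/C=C3\OC(=O)C(OCc4ccccc4)=C3OCc3ccccc3)nn2)cc1` reaches only the limit > 100000 nM in this assay, so it stands at the weak end of what has been measured. Among the measured compounds shown here, the single measured change, an at least 5.6-fold higher number from compound 1 to compound 2 (0.75 log units; beyond the scatter), swapped one aryl group for another. Compound 3 `COc1ccccc1-c1cn(C/C=C2\OC(=O)C(OCc3ccccc3)=C2OCc2ccccc2)nn1` differs from compound 2 by 2-methoxyphenyl in place of 4-methoxyphenyl on an aromatic carbon; no measured step covers a change of this kind, so the one step shown does not bear directly on it. Compound 3 is therefore expected to remain weak, estimated at 80000 nM with a range of 20000 nM to 300000 nM. The step of an at least 1.2-fold lower number from compound 2 to compound 3 (0.09 log units; that floor lies within the scatter) is expected to be small.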

Compound 3, half-maximal inhibitory concentration: > 100000 nM
Compound 3: a limit, no number; the forecaster's own chance of this, stated with the estimate: 55%; middle value at least 1.2-fold (0.09 log units) away from the limit.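

In this assay, 2-methoxyphenyl in place of 3,5-difluorophenyl gives an at least 5.6-fold higher number from compound 1 to compound 3 (0.75 log units; beyond the scatter), so the higher number seen with 4-methoxyphenyl is not confined to that one methoxyphenyl isomer. The step from compound 2 to compound 3 cannot be read, because both compounds rest at a limit, not a number: the limit of > 100000 nM in this assay, at which 2 of the 3 values shown sit.

The two methoxyphenyl isomers therefore cannot be ordered at this position. Still open, as far as these compounds go, is whether a phenyl ring carrying an amine or a carboxylic acid on this aromatic carbon would give a lower number than compound 1.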